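Moving from a branched to a straight chain on the ring nitrogen

The source may hold more compounds than are shown below. What is called first, only, known or untested is meant among the compounds shown, and "the series" means these compounds.

Compound 1 `O=C1C=C(Cl)C(O)(c2ccc(Cl)cc2)N1C1CCCC1` and compound 2 `CC(C)CN1C(=O)C=C(Cl)C1(O)c1ccc(Cl)cc1` share a core and differ only in the group on the amide-type nitrogen in the ring. In an assay on cell membranes for displacement of a labelled ligand from Cholecystokinin receptor type A (Rattus norvegicus), read by CCK-8 assay, with a stated time of 2 h (a higher number here means a weaker inhibitor, a lower number a stronger inhibitor), compound 1 gives 2500 nM, while compound 2 gives 8 nM, a change of a 310-fold lower number from compound 1 to compound 2 (2.49 log units; beyond the scatter). Going by the values given here, compound 2 therefore stands as the lower of the two numbers in this assay, and the one step seen so far shows that this nitrogen substituent can shift the result strongly.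

Compound 3 `CCCCCCN1C(=O)C=C(Cl)C1(O)c1ccc(Cl)cc1` continues at the same place: pentyl in place of isopropyl on a saturated chain carbon bound to an amide-type nitrogen in a ring. Among the compounds with values here, no measured pair tests a straight chain against a branched one here, so the step from compound 1 to compound 2 only warns that the change may matter. Compound 3 is expected to show a modest step of a 3.8-fold higher number from compound 2 to compound 3 (0.57 log units; beyond the scatter), with an estimate of 30 nM, within a range from 5 nM to 200 nM in this assay.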

Compound 3, half-maximal inhibitory concentration: 3600 nM
The estimate for compound 3 lay 120-fold (2.08 log units) below the measured number; measured number outside the range, above it.
By their numbers in this assay, from the lowest: compound 2; then compounds 1 and 3 (each within the scatter of the next).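

In this assay, the step of a 450-fold higher number from compound 2 to compound 3 (2.65 log units; beyond the scatter) shows that this position tolerates little change: replacing isopropyl with pentyl on the saturated chain carbon loses almost all of the low number seen for compound 2. The step of a 1.4-fold higher number from compound 1 to compound 3 (0.16 log units; within the scatter) lies within the scatter, so hexyl and cyclopentyl on the amide-type nitrogen in the ring cannot be told apart here, and among these three compounds only the isobutyl of compound 2 stands out. Nothing available explains this sharp difference.

Hexyl differs from isobutyl in both length and branching, so the compounds shown leave open which of the two matters. A straight butyl chain and a longer branched chain such as 4-methylpentyl would help separate them.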